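The source may hold more compounds than are shown below. What is called first, only, known or untested is meant among the compounds shown, and "the series" means these compounds.

Among the three compounds measured so far in a functional assay on MGC-803 cells (Homo sapiens) for inhibition, read by CCK-8 assay, with a stated time of 48 h (on this read-out higher numbers stand for weaker inhibition and lower numbers for stronger inhibition), compound 3 (`COc1ccc(CN(C(=O)CSC(=S)N2CCN(C(=O)OC(C)(C)C)CC2)c2cc(OC)c(OC)c(OC)c2)cc1O`) has the lowest number, at 82 nM. Compound 2 (`COc1ccc(CN(C(=O)CSC(=S)N2CCN(C(=O)OC(C)(C)C)CC2)c2cc(OC)c(OC)c(OC)c2)cc1F`) gives 4870 nM, and compound 1 (`CCN1CCN(C(=S)SCC(=O)N(Cc2ccc(OC)cc2)c2cc(OC)c(OC)c(OC)c2)CC1`) gives 9890 nM. Compound 4 (`CCN1CCN(C(=S)SCC(=O)N(Cc2ccc(OC)c(O)c2)c2cc(OC)c(OC)c(OC)c2)CC1`) is made from compound 3 by a single change, ethyl in place of tert-butoxycarbonyl on an amine nitrogen in a ring.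

Among the compounds with values here, the only measured single-place step is a 59-fold lower number from compound 2 to compound 3 (1.77 log units; beyond the scatter), a large step beyond the scatter, made by hydroxy in place of fluoro on an aromatic carbon. Compound 4 keeps that hydroxy, so this step suggests that it will stay near compound 3. Within the data shown here, no measured step isolates the swap from tert-butoxycarbonyl to ethyl. Compound 1 carries the ethyl but lacks the hydroxy, so it differs from compound 2 in more than one place and cannot settle the question.

The expected change in this assay is a 1.5-fold higher number from compound 3 to compound 4 (0.17 log units; within the scatter), a small rise that stays within the scatter, though with real uncertainty. For compound 4 the estimated value is 120 nM, with an expected range of 25 nM to 600 nM.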

Compound 4, half-maximal inhibitory concentration: 380 nM
Compound 4: the middle estimate sits 3.2-fold (0.50 log units) below what was measured, and the stated range covers the measured number.
By their numbers in this assay, from the lowest: compound 3; then compound 4; then compound 2; then compound 1.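

Changing the group on the ring nitrogen matters even with the hydroxy in place: in this assay, ethyl in place of tert-butoxycarbonyl gives a 4.6-fold higher number from compound 3 to compound 4 (0.67 log units; beyond the scatter), a modest loss of inhibition. The hydroxy also proves useful in a second setting, as adding it to the aromatic carbon in the ethyl series gives a 26-fold lower number from compound 1 to compound 4 (1.42 log units; beyond the scatter). Within these compounds, the hydroxy therefore goes with stronger inhibition alongside either nitrogen group, first against fluoro and now against hydrogen.

Nothing here gives a measured reason for either step. Still open, from the compounds shown here alone, is how a longer alkyl chain or an acetyl group on the ring nitrogen would compare, and whether an amine on the aromatic carbon could take the place of the hydroxy.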